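Piperidine Amide Replaces Ethylene-Linked Amide on the Shared Core

A few compounds are considered here, and "the series" means these few. Any claim that something is new, unique, unknown or untested is made for them only; others in the source may bear on it.

The study gathers four compounds on a shared core. Compound 1 `Cc1nc(N2CCC(N3CCCC3=O)CC2)nc2ccc(NC(=O)/C=C/c3ccc(Cl)cc3)cc12` gives 50% in an ADME assay on microsomes from liver (Homo sapiens) for metabolic stability, with a stated time of 30 min; a lower number here means that less of the compound is left, a higher number that more of the compound is left. Compound 2 `Cc1nc(N2CCC(O)(C3CC3)CC2)nc2ccc(NC(=O)COc3ccc(OC(F)(F)F)cc3)cc12` is recorded in this assay as "not determined" (no result reported), and compound 3 `Cc1nc(NCCNC(=O)C2CC2)nc2ccc(NC(=O)/C=C/c3ccc(OC(F)(F)F)cc3)cc12` likewise as "not determined" (no result reported): compound 3 stands without a single number, and one further entry shares that position. Compound 4 `COCC(=O)NC1CCN(c2nc(C)c3cc(NC(=O)/C=C/c4ccc(OC(F)(F)F)cc4)ccc3n2)CC1` differs from compound 3 in one place: 4-(((methoxymethyl)carbonyl)amino)piperidin-1-yl in place of (2-((cyclopropylcarbonyl)amino)ethyl)amino on an aromatic carbon. For the measured compounds named here, no step between measured compounds connects the two, so the size of the change in this assay cannot be read from the data; with compound 1 as the only measured anchor, a moderate result in that region is expected rather than a shift in a known direction. Compound 4 is therefore estimated at 45% in this assay, with a range from 20% to 75%.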

Compound 4, percent of the compound remaining: 58%
Estimate against measurement, compound 4: 13 percentage points below; low and high end bracket the measured number.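

No new step can be read between compound 3 and compound 4 in this assay, and nothing at hand accounts for the result of compound 4. The compounds shown leave open how far 4-(((methoxymethyl)carbonyl)amino)piperidin-1-yl in place of (2-((cyclopropylcarbonyl)amino)ethyl)amino moves the result in this assay, and in which direction.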